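The compounds below may be only part of what the source reports. "The series", "measured", "known", "first", "only" and "open" are said of these compounds alone.

Compound 2 `COc1cccc(C(=O)Nc2cccc(-c3oc4cc(-c5ccc(F)cc5)ccc4c(=O)c3O)c2)c1` carries a 3-methoxyphenyl on the carbonyl carbon of its amide. Going by the values given here, in a functional assay on MCF7 cells (Homo sapiens) for antiproliferative activity, read by CCK-8 assay, with a stated time of 72 h (on this read-out higher numbers stand for weaker inhibition and lower numbers for stronger inhibition), compound 2 gives 15300 nM, the highest of the two numbers measured so far. Among the compounds with values here, its only neighbour is compound 1 `O=C(Nc1cccc(-c2oc3cc(-c4ccc(F)cc4)ccc3c(=O)c2O)c1)c1ccccc1F`, which in this assay gives 7570 nM; between them lies a 2.0-fold higher number from compound 1 to compound 2 (0.31 log units; beyond the scatter). Compound 3 `CCc1ccc(C(=O)Nc2cccc(-c3oc4cc(-c5ccc(F)cc5)ccc4c(=O)c3O)c2)cc1` differs from compound 2 at this same place: 4-ethylphenyl in place of 3-methoxyphenyl on a carbonyl carbon. Within the data shown here, the one measured step that bears on this change is the step from compound 1 to compound 2, which also swapped the aryl group on the carbonyl carbon, and that step was modest. Among the measured compounds shown here, no measured compound carries a 4-ethylphenyl, so the direction of the new step is open. The step is expected to be small, a 1.4-fold lower number from compound 2 to compound 3 (0.14 log units; within the scatter), most likely within the scatter. Compound 3 is therefore estimated at 11000 nM, with a range from 4500 nM to 27000 nM.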

Compound 3, half-maximal inhibitory concentration: 22800 nM
Compound 3: the middle estimate sits 2.1-fold (0.32 log units) below what was measured, within the range that was stated.
By their numbers in this assay, from the lowest: compound 1; then compounds 2 and 3 (each within the scatter of the next).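

In this assay, 4-ethylphenyl in place of 3-methoxyphenyl on the carbonyl carbon gives a 1.5-fold higher number from compound 2 to compound 3 (0.17 log units; within the scatter), so these two aryl groups cannot be told apart here, even though the entering group holds carbon only and the leaving group holds an oxygen. The step in the other direction of comparison, a 3.0-fold higher number from compound 1 to compound 3 (0.48 log units; beyond the scatter), is beyond the scatter and joins a 2.0-fold higher number from compound 1 to compound 2 (0.31 log units; beyond the scatter): both replacements of 2-fluorophenyl give a higher number, a modest change in each case, and no compound shown goes against this. Nothing measured here explains this difference in the antiproliferative read-out. Whether the fluorine itself accounts for the lower number of compound 1 stays open. Also open, going by these compounds, is how this position would respond to a non-aromatic group such as cyclohexyl, or to a phenyl carrying an amine or a carboxylic acid.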